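Indazole substituent variation in a diaryl urea series

A few compounds are considered here, and "the series" means these few. Any claim that something is new, unique, unknown or untested is made for them only; others in the source may bear on it.

Compound 1 `O=C(Nc1ccc(-n2ncc3c(Br)cccc32)cc1)Nc1ccc(Cl)c(C(F)(F)F)c1` and compound 2 `O=C(Nc1ccc(-n2ncc3c(F)cccc32)cc1)Nc1ccc(Cl)c(C(F)(F)F)c1` share a diaryl urea core and differ only at one aromatic carbon of the fused ring. For the measured compounds named here, in a functional assay on NCI-H460 cells (Homo sapiens) for cytotoxicity, read by MTT assay, with a stated time of 72 h (on this read-out higher numbers stand for weaker inhibition and lower numbers for stronger inhibition), compound 1 gives 1300 nM, while compound 2 gives 3400 nM, the highest of the two numbers known so far; the step of a 2.6-fold higher number from compound 1 to compound 2 (0.42 log units; beyond the scatter) is the only measured step and it bears directly on the next change. Compound 3 `Cc1cccc2c1cnn2-c1ccc(NC(=O)Nc2ccc(Cl)c(C(F)(F)F)c2)cc1` is the unmeasured analogue: methyl in place of fluoro on an aromatic carbon. Going by the values given here, the single relevant step shows that the smallest group at this position gives the weaker result, so a move to methyl is expected to give a somewhat lower number, though the step may not exceed the scatter. Compound 3 is therefore estimated at 2000 nM, with a range of 800 nM to 5000 nM, corresponding to an expected step of a 1.7-fold lower number from compound 2 to compound 3 (0.23 log units; within the scatter).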

Compound 3, half-maximal inhibitory concentration: 2500 nM
Compound 3: the middle estimate sits 1.3-fold (0.10 log units) below what was measured; measured number inside the range.
By their numbers in this assay, from the lowest: compounds 1, 3 and 2 (each within the scatter of the next, the first and the last beyond it).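

In this assay the methyl analogue cannot be ordered against either halogen analogue: the printed steps are a 1.4-fold lower number from compound 2 to compound 3 (0.13 log units; within the scatter) and a 1.9-fold higher number from compound 1 to compound 3 (0.28 log units; within the scatter). Of the three substituents at this aromatic carbon, only the bromo and fluoro pair stands apart beyond the scatter, so methyl in place of fluoro adds no separate level to the series and does not show a trend across the three groups. No measurement at hand offers an explanation for these numbers.

Still open, on these data alone, is whether an amine, a methoxy group or a longer chain such as propyl on this carbon would move the number beyond the scatter of all three compounds. Also open, as far as these compounds go, is whether the same substituent changes would read alike in another cell line.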